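Swapping the aryl group on the ring nitrogen

The source may hold more compounds than are shown below. What is called first, only, known or untested is meant among the compounds shown, and "the series" means these compounds.

Of the compounds shown here, three sharing one core have been measured in a functional assay on PC-3 cells (Homo sapiens) for inhibition, read by MTT assay, with a stated time of 72 h; on this read-out lower numbers stand for stronger inhibition and higher numbers for weaker inhibition. Compound 1 `O=C(CSc1nc(Nc2ccccc2)c2ccccc2n1)Nc1ccc(C(F)(F)F)cc1` gives 10400 nM. Compound 2 `O=C(CSc1nc(Nc2ccccc2)c2ccccc2n1)Nc1ccc(Cl)c(Cl)c1` gives 12100 nM; the step of a 1.2-fold higher number from compound 1 to compound 2 (0.07 log units; within the scatter) is therefore too small to count. Compound 3 `C=CC(=O)Nc1cccc(NC(=O)CSc2nc(Nc3ccccc3Cl)c3ccccc3n2)c1` gives 14400 nM, and its number sits alongside those of compound 1 and compound 2, within the scatter of both, so the three cannot be told apart on this read-out.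

Compound 4 `C=CC(=O)Nc1cccc(NC(=O)CSc2nc(Nc3cc(OC)c(OC)c(OC)c3)c3ccccc3n2)c1` is the next structure to be tested. It differs from compound 3 in one place: 3,4,5-trimethoxyphenyl in place of 2-chlorophenyl on a nitrogen on an aromatic ring. For the measured compounds named here, no measured step touches this nitrogen on an aromatic ring; the only step available, the one from compound 1 to compound 2, changes the group on the amide-type nitrogen instead and stayed within the scatter. With nothing in the data pointing to a change beyond the scatter at this position, the expected step of a 1.2-fold lower number from compound 3 to compound 4 (0.08 log units; within the scatter) is set near zero. On that basis compound 4 is expected to give about 12000 nM in this assay, with a range from 4000 nM to 40000 nM.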

Compound 4, half-maximal inhibitory concentration: > 50000 nM
Compound 4 ended at the assay's limit; the forecaster's own chance of this, stated with the estimate: 10%; at least 4.1-fold (0.61 log units) between middle value and limit.
By their numbers in this assay, from the lowest: compounds 1, 2 and 3 (each within the scatter of the next). At a limit, above all of these: compound 4.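

Replacing 2-chlorophenyl with 3,4,5-trimethoxyphenyl on the nitrogen on an aromatic ring gives, in this assay, an at least 3.4-fold higher number from compound 3 to compound 4 (0.54 log units; beyond the scatter). The only earlier step, a 1.2-fold higher number from compound 1 to compound 2 (0.07 log units; within the scatter), changed the group on the amide-type nitrogen and stayed within the scatter, so this is the first sign among these compounds that a change of group can shift the number clearly, and here it weakens inhibition. Compound 4 gives > 50000 nM, which is a limit of the assay and not a number, so the step has a known minimum but no known size: the limit of > 50000 nM in this assay, at which 1 of the 4 values shown sits.

The swap changes several things at once: the chlorine goes, the group grows from 7 to 12 heavy atoms, and 3 hydrogen-bond acceptors arrive, so the result cannot say which of these matters. Still open, on these data alone, is how this nitrogen would respond to a smaller or simpler group, such as a phenyl ring carrying a single methoxy group, a benzyl group or a plain ethyl chain, any of which would help separate these changes.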